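The source may hold more compounds than are shown below. What is called first, only, known or untested is meant among the compounds shown, and "the series" means these compounds.

Measured so far:
compound 1, `CC(C)[C@H](NC(=O)CCN(C)C)c1cccc(F)c1N1CCN(C(=O)[C@@H]2CN(C(C)C)C[C@H]2c2cc(F)c(F)c(F)c2)CC1`, 250 nM in an assay on HEK293 cells for displacement of a labelled ligand from Melanocortin receptor 4 (Homo sapiens); on this read-out lower numbers stand for stronger inhibition and higher numbers for weaker inhibition
compound 2, `CC(C)[C@H](NC(=O)CCN(C)C)c1cccc(F)c1N1CCN(C(=O)[C@@H]2CN(C(C)C)C[C@H]2c2ccc(F)c(Cl)c2)CC1`, 260 nM
compound 3, `CC(C)[C@H](NC(=O)CCN(C)C)c1cccc(F)c1N1CCN(C(=O)[C@@H]2CN(C(C)C)C[C@H]2c2ccc(C(F)(F)F)c(F)c2)CC1`, 51 nM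

All three compounds share one core and differ only in the aryl group on the saturated ring carbon. Compound 3 gives the lowest number of the three: the step of a 4.9-fold lower number from compound 1 to compound 3 (0.69 log units; beyond the scatter) and the step of a 5.1-fold lower number from compound 2 to compound 3 (0.71 log units; beyond the scatter) both go beyond the scatter, while the step of a 1.0-fold higher number from compound 1 to compound 2 (0.02 log units; within the scatter) does not. Compound 4, `CC(C)[C@H](NC(=O)CCN(C)C)c1cccc(F)c1N1CCN(C(=O)[C@@H]2CN(C(C)C)C[C@H]2c2ccc(C(F)(F)F)cc2F)CC1`, keeps the trifluoromethyl-bearing aryl of compound 3 but moves the fluorine: 2-fluoro-4-(trifluoromethyl)phenyl in place of 3-fluoro-4-(trifluoromethyl)phenyl on a saturated ring carbon.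

Among the measured compounds shown here, no measured step swaps the fluorine position while keeping the trifluoromethyl, so the two steps into compound 3 are the nearest guide. They show that a change in the aryl substitution pattern can shift the number modestly, and in this series the fluoro-trifluoromethyl aryl of compound 3 stands apart from the other two. Since the same atoms are kept and only rearranged, a shift no larger than those steps is expected, most likely back toward the level of compound 1 and compound 2 rather than further down. Compound 4 is therefore expected to give 110 nM, within 40 nM to 300 nM, a step of a 2.2-fold higher number from compound 3 to compound 4 (0.33 log units; beyond the scatter).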

Compound 4, inhibition constant: 61 nM
For compound 4 the middle estimate is 1.8-fold (0.26 log units) above the measured one, within the range that was stated.
By their numbers in this assay, from the lowest: compounds 3 and 4 (each within the scatter of the next); then compounds 1 and 2 (each within the scatter of the next).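

In this assay, among the compounds shown here, 2-fluoro-4-(trifluoromethyl)phenyl in place of 3-fluoro-4-(trifluoromethyl)phenyl on this saturated ring carbon gives a 1.2-fold higher number from compound 3 to compound 4 (0.08 log units; within the scatter), so rearranging these same atoms leaves no change that can be told from the scatter, something the earlier steps, which all changed the substituents themselves, could not show. Compound 4 also keeps clear of the two aryl groups without trifluoromethyl, with a 4.3-fold lower number from compound 2 to compound 4 (0.63 log units; beyond the scatter) and a 4.1-fold lower number from compound 1 to compound 4 (0.61 log units; beyond the scatter), so among these four compounds the lower numbers belong to both trifluoromethyl-bearing aryl groups, and no compound goes against this, which means the low number of compound 3 is not specific to its one fluorine arrangement. No supporting data bear on this result, so the pattern can be described here but not explained.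

The compounds shown leave open whether the trifluoromethyl group is enough without any ring fluorine, as a plain 4-(trifluoromethyl)phenyl would test. They also leave open whether a nitrile or a methoxy group in the place of the trifluoromethyl would hold the number at the level of compound 3 and compound 4 or return it to that of compound 1 and compound 2.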